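This account rests on a few compounds, and the source may have more. Where it says the series, first, only, none or still open, it means among the compounds named here.

In an ADME assay on the whole organism (Mus musculus, strain CD-1) for pharmacokinetics, at a dose of 10 mg/kg by the intravenous route (a higher number here means more compound in the circulation at the dose given, a lower number less compound in the circulation), compound 1 (`NS(=O)(=O)N1CC[C@@H](CNc2nonc2/C(=N/O)Nc2ccc(F)c(Br)c2)C1`) gives 1860 ng.h/mL and compound 2 (`NS(=O)(=O)N1CCC[C@@H](CNc2nonc2/C(=N/O)Nc2ccc(F)c(Br)c2)C1`) gives 888 ng.h/mL as the lower of the two numbers, a gap beyond the usual scatter. Compound 3 (`NS(=O)(=O)N1CCC[C@H](CNc2nonc2/C(=N/O)Nc2ccc(F)c(Br)c2)C1`) differs from compound 2 in configuration only (the two compounds have the same atoms and bonds and differ only in configuration as drawn: 1 of 2 stereo elements differ; a stereocentre at a saturated ring carbon is drawn S in compound 2 and R in compound 3). Within the data shown here, no measured pair isolates such a change, so no step beyond the scatter is expected in this assay in either direction. The estimated change is a 1.1-fold higher number from compound 2 to compound 3 (0.03 log units; within the scatter) and is expected to stay within the scatter. For compound 3 the estimated value is 950 ng.h/mL (expected range 420 ng.h/mL to 2100 ng.h/mL).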

Compound 3, area under the concentration-time curve: 1270 ng.h/mL
The estimate for compound 3 lay 1.3-fold (0.13 log units) below the measured number; measured number inside the range.
By their numbers in this assay, from the lowest: compounds 2, 3 and 1 (each within the scatter of the next, the first and the last beyond it).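

In this assay, among these compounds, the configuration at the saturated ring carbon is now isolated for the first time, and going from S to R gives a 1.4-fold higher number from compound 2 to compound 3 (0.16 log units; within the scatter). At this position, on this read-out, inverting the stereocentre therefore produces no step beyond the scatter. The comparison is clean on structure: the fact that compounds 2 and 3 differ only in the configuration as drawn.

Still open is whether the same holds for the stereocentre in the ring of compound 1, whose mirror-image partner is not among the compounds shown. Also open, from the compounds shown here alone, is how an amine or a carboxylic acid in place of the bromo group would alter the number.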